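The compounds below may be only part of what the source reports. "The series", "measured", "known", "first", "only" and "open" are said of these compounds alone.

Compound 1 `COc1ccc(-n2nc(C(F)(F)F)cc2C(=O)Cc2ccc(-c3ccccc3S(N)(=O)=O)cc2)cc1`: > 2500 nM
Compound 2 `Nc1noc2ccc(-n3nc(C(F)(F)F)cc3C(=O)Cc3ccc(-c4ccccc4S(N)(=O)=O)cc3)cc12`: > 20000 nM

In an assay on isolated protein for inhibition of Trypsin (Homo sapiens) (a lower number here means a stronger inhibitor, a higher number a weaker inhibitor), compound 1 gives > 2500 nM, which is a limit of the assay and not a number. Compound 2 gives > 20000 nM, likewise a limit. The step that the two limits leave unreadable from compound 1 to compound 2 rests on the limit of > 20000 nM in this assay, at which 1 of the 2 values shown sits, and the limit of > 2500 nM in this assay, at which 1 of the 2 values shown sits, and yields no readable size. Compound 3 `COc1ccc(-n2nc(C(F)(F)F)cc2C(=O)Cc2ccc(-c3ccccc3CN3CC[C@H](O)C3)cc2)cc1` differs from compound 1 by (3-hydroxypyrrolidin-1-yl)methyl in place of sulfamoyl on an aromatic carbon. Going by the values given here, no measured step bears on this change, and compound 1 itself stands only at a limit, so neither direction nor size can be drawn from what has been measured. Compound 3 is therefore estimated at 5000 nM. For compound 3 the expected range runs from 1000 nM to 30000 nM. The step that the limit leaves unreadable from compound 1 to compound 3 is the expected size of this change, not beyond the scatter.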

Compound 3, inhibition constant: > 4200 nM
Compound 3 was reported as a limit; the forecaster's own chance of this, stated with the estimate: 65%; the middle value is on the limit's open side.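

Compound 1 and compound 3 both stand only at limits in this assay, so the step between them cannot be read. The compounds shown leave open whether (3-hydroxypyrrolidin-1-yl)methyl in place of sulfamoyl changes inhibition at all.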